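The source may hold more compounds than are shown below. What is called first, only, known or untested is meant among the compounds shown, and "the series" means these compounds.

In a functional assay on MCF7 cells (Homo sapiens) for inhibition (on this read-out higher numbers stand for weaker inhibition and lower numbers for stronger inhibition), compound 1 (`CCN(C(=O)CC(CC(=O)NCCN1CCCCC1)c1ccc(Cl)cc1)C1Cc2ccccc2C1`) gives 16500 nM. Compound 2 (`CCN(C(=O)CC(CC(=O)NCCN1CCCC1)c1ccccc1)C1Cc2ccccc2C1`) gives > 100000 nM, which is a limit of the assay and not a number. Compound 3 (`CCN(C(=O)CC(CC(=O)NCCN1CCCCC1)c1ccccc1)C1Cc2ccccc2C1`) has piperidin-1-yl in place of pyrrolidin-1-yl on a saturated chain carbon, two bonds along the chain from an amide-type nitrogen. This single ring change is expected to bring a modest shift toward stronger inhibition, an estimated at least 1.8-fold lower number from compound 2 to compound 3 (0.25 log units; that floor lies within the scatter). For compound 3, the expected value is 55000 nM, with an estimated range of 20000 nM to 100000 nM.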

Compound 3, half-maximal inhibitory concentration: > 100000 nM
Compound 3 was reported as a limit; the forecaster's own chance of this, stated with the estimate: 35%; middle value at least 1.8-fold (0.25 log units) away from the limit.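

In this assay compound 2 and compound 3 both stand at a limit and not at a number, so the change from pyrrolidin-1-yl to piperidin-1-yl cannot be read: the limit of > 100000 nM in this assay, at which 2 of the 3 values shown sit. The new information lies on the aromatic carbon, where hydrogen in place of chloro gives an at least 6.0-fold higher number from compound 1 to compound 3 (0.78 log units; beyond the scatter). In this one pair, which keeps piperidin-1-yl, the chloro goes with the stronger inhibition.

From the compounds shown here alone, it remains open whether chloro would bring a readable value with pyrrolidin-1-yl as well. Going by these compounds, it is also open whether fluoro or methoxy on that aromatic carbon would act as chloro does.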